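The compounds below may be only part of what the source reports. "The series", "measured", "known", "first", "only" and "open" are said of these compounds alone.

Compound 1 `COc1ccc2nc(-c3ccc(C)c(N)c3)sc2c1` carries a methoxy group on the fused ring system. In a functional assay on HL-60 cells (Homo sapiens) for cytotoxicity, read by MTT assay, with a stated time of 2 days (a higher number here means a weaker inhibitor, a lower number a stronger inhibitor), compound 1 gives only a limit of the assay, > 50000 nM. Compound 2 `Cc1ccc(-c2nc3ccc(F)cc3s2)cc1N` carries fluoro in that place. In this assay compound 2 likewise gives only a limit, > 50000 nM. The step from compound 1 to compound 2 is a step that the two limits leave unreadable from compound 1 to compound 2. Both values sit at the limit of > 50000 nM in this assay, at which 2 of the 2 values shown sit. Compound 2 therefore stands at the limit on the numbers shown, with no readable value anywhere in the series so far. Compound 3 `Cc1ccc(-c2nc3ccccc3s2)cc1N` differs from compound 2 by hydrogen in place of fluoro on an aromatic carbon. For the measured compounds named here, only one measured step exists in this assay, and it is unreadable, so no measured step gives a readable size for this change. No movement beyond the scatter can be expected from the data; compound 3 is expected to stay at the limit. The expected step is a number no higher from compound 2 to compound 3 (the limit leaves the size open). For compound 3 the estimate in this assay is 50000 nM, within a range from 15000 nM to 200000 nM.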

Compound 3, half-maximal inhibitory concentration: > 50000 nM
Compound 3 gave a limit, no number; the forecaster's own chance of this, stated with the estimate: 80%; the middle value lies on the limit itself.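

No new step can be read: compound 1, compound 2 and compound 3 all give only a limit in this assay, which leaves each step between them unreadable: the limit of > 50000 nM in this assay, at which 3 of the 3 values shown sit.

The compounds shown leave open whether methoxy, fluoro and hydrogen on the shared core differ at all in this assay.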